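Moving to 4-chlorophenyl on the carbonyl carbon

A few compounds are considered here, and "the series" means these few. Any claim that something is new, unique, unknown or untested is made for them only; others in the source may bear on it.

Measured in a functional assay on ACHN cells (Homo sapiens) for cytotoxicity, read by sulforhodamine B assay, with a stated time of 72 h; a higher number here means a weaker inhibitor of growth, a lower number a stronger inhibitor of growth:
compound 1 `O=C(Nc1ccccc1C(F)(F)F)C1CCc2ccccc2N1`: 57600 nM
compound 2 `O=C(Nc1ccccc1C(F)(F)F)C1CCc2ccccc2N1C(=O)c1cccc(Cl)c1`: 526 nM

Going by the values given here, compound 2, at 526 nM, holds the lower of the two numbers so far. Compound 3 `O=C(Nc1ccccc1C(F)(F)F)C1CCc2ccccc2N1C(=O)c1ccc(Cl)cc1` is the next to be read in this assay. It has the same atoms as compound 2, joined differently: 4-chlorophenyl in place of 3-chlorophenyl on a carbonyl carbon.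

Among the compounds with values here, only one measured step bears on this change, and only indirectly. The large step of a 110-fold lower number from compound 1 to compound 2 (2.04 log units; beyond the scatter) lies beyond the scatter, but it records (3-chlorophenyl)carbonyl in place of hydrogen, not an exchange of one chlorophenyl group for another. Within the data shown here, no measured pair makes that exchange, so its direction cannot be read from the data. The (4-chlorophenyl)carbonyl group of compound 3 still replaces that hydrogen, so most of the drop seen in that step is expected to persist, with no shift beyond the scatter in either direction. The expected step is a 1.2-fold higher number from compound 2 to compound 3 (0.09 log units; within the scatter), which stays within the scatter. For compound 3 the estimated value is 650 nM, with an expected range from 220 nM to 1900 nM, and the measurement follows.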

Compound 3, concentration for 50% growth inhibition: 824 nM
Beside the measured number, compound 3's estimate is 1.3-fold (0.10 log units) below it; low and high end bracket the measured number.
By their numbers in this assay, from the lowest: compounds 2 and 3 (each within the scatter of the next); then compound 1.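

In this assay, exchanging 3-chlorophenyl for 4-chlorophenyl on a carbonyl carbon gives a 1.6-fold higher number from compound 2 to compound 3 (0.19 log units; within the scatter), so compound 2 and compound 3 cannot be told apart here, and this exchange leaves the read-out within the usual scatter. The large step from the compound with the free ring nitrogen holds with either chlorophenyl group: a 70-fold lower number from compound 1 to compound 3 (1.84 log units; beyond the scatter) stands alongside a 110-fold lower number from compound 1 to compound 2 (2.04 log units; beyond the scatter), which shows that this step does not depend on one particular chlorophenyl isomer among the two compared. No measurement shown here explains either the large steps or the absence of a clear difference between the two isomers.

Going by these compounds, what remains open is whether the chlorine is needed at all, since these compounds do not show a plain phenyl group, a pyridine ring or a short alkyl chain on this carbonyl carbon. Also open, on these data alone, is how far the large step depends on the rest of the molecule, as all three compounds carry the same 2-(trifluoromethyl)phenyl amide, and neither a nitrile nor a carboxylic acid appears on that ring.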